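Tolerance of Four Related Compounds on Liver Cells

The compounds below may be only part of what the source reports. "The series", "measured", "known", "first", "only" and "open" are said of these compounds alone.

Compound 1 `C=C1CC[C@@H]2[C@](C)(COC(C)=O)[C@H](O)CC[C@@]2(C)[C@@H]1/C=C/C1=CCOC1=O` — 225000 nM
Compound 2 `C=C1CC[C@@H]2[C@](C)(COC(C)=O)[C@H](O)CC[C@@]2(C)[C@@H]1C/C=C1\C=COC1=O` — 334000 nM
Compound 3 `C=C1CC[C@H]2[C@@](C)(CCC(=O)[C@@]2(C)C=O)[C@@H]1/C=C/C1=CCOC1=O` — 275000 nM

Of the compounds shown here, three have been measured in an ADME assay on HepG2 2.2.15 cells (Homo sapiens) for cytotoxicity, read by MTT assay; a higher number here means that more compound is tolerated, a lower number that less compound is tolerated. Compound 1 and compound 2 share one core and differ only in a group of 8 heavy atoms (6 carbon, 2 oxygen; one five-membered non-aromatic ring with 1 hetero atom) in place of a group of 8 heavy atoms (6 carbon, 2 oxygen; one five-membered non-aromatic ring with 1 hetero atom), on a saturated ring carbon. That change gave a 1.5-fold higher number from compound 1 to compound 2 (0.17 log units; within the scatter), so the two numbers are not distinguishable by this assay. Compound 3 carries a different core; the difference between the two cores is not broken down here. In this assay compound 3 gives 275000 nM, which lies within the scatter of both compound 1 and compound 2.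

Compound 4 `C=C1CC[C@H]2[C@@](C)(CCC(=O)[C@@]2(C)C=O)[C@@H]1C/C=C1\C=COC1=O` has not yet been measured. It differs from compound 3 by a group of 8 heavy atoms (6 carbon, 2 oxygen; one five-membered non-aromatic ring with 1 hetero atom) in place of a group of 8 heavy atoms (6 carbon, 2 oxygen; one five-membered non-aromatic ring with 1 hetero atom), on a saturated ring carbon. The place of the change is described in the same words for both pairs, so this is the same change as that from compound 1 to compound 2, made on the core of compound 3 instead.

Because that change gave a 1.5-fold higher number from compound 1 to compound 2 (0.17 log units; within the scatter) on the first core, the step expected here is a 1.3-fold higher number from compound 3 to compound 4 (0.12 log units; within the scatter), a shift too small to be told from the scatter. For compound 4 in this assay the estimated value is 360000 nM, with a likely range from 170000 nM to 750000 nM. This rests on a single earlier example of the change and on the closeness of compound 3 to compound 1 and compound 2.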

Compound 4, half-maximal cytotoxic concentration: 964000 nM
Beside the measured number, compound 4's estimate is 2.7-fold (0.43 log units) below it, and the stated range ends below it.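

On the core of compound 3, exchanging one group for the other on the saturated ring carbon gave, in this assay, a 3.5-fold higher number from compound 3 to compound 4 (0.54 log units; beyond the scatter), a step that lies beyond the scatter, whereas the earlier step on the other core lies within it. Even so, when the two steps are set side by side, the gap between them does not exceed what repeated measurement could produce: the same change on two cores in this assay, a 1.5-fold higher number (0.17 log units; within the scatter) from compound 1 to compound 2 and a 3.5-fold higher number (0.54 log units; beyond the scatter) from compound 3 to compound 4, 2.4-fold (0.37 log units) apart, within the scatter of two such steps

This shows no difference in how the change behaves on the two cores, but it does not show that the change has the same size on both or that one core enlarges it, and a single pair on each core cannot establish a rule for the series.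

All of the compounds shown carry one of these two forms of the five-membered ring with one hetero atom, so it remains open what an amine or a carboxylic acid on that ring, or a longer chain joining it to the saturated ring carbon, would do in this assay. On these data alone, it is also open whether the same change would give a comparable step on a third core.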